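The compounds below may be only part of what the source reports. "The series", "measured", "known", "first", "only" and "open" are said of these compounds alone.

Compound 1 `N#C/C(=C\c1ccco1)C(=O)NCc1ccc(Cl)c(Cl)c1` and compound 2 `COc1ccc(CNC(=O)/C(C#N)=C/c2cccc3ccccc23)cc1` share a core, and both have been tested in a functional assay on MIA cells (Homo sapiens) for inhibition, read by MTT assay, with a stated time of 72 h; a lower number here means a stronger inhibitor of growth, a higher number a weaker inhibitor of growth. For compound 1 this assay reports only a limit, > 50000 nM, not a measured number. The same stands out in the limit of > 50000 nM in this assay, at which 1 of the 2 values shown sits. In this assay compound 2 gives 15000 nM. Among the compounds with values here, compound 2 differs from compound 1 in more than one place, and no step between two measured compounds that differ in a single place exists, so the two values can only be set side by side.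

Compound 3 `N#C/C(=C\c1ccc(Cl)cc1)C(=O)NCc1ccc(Cl)c(Cl)c1` has not yet been tested. It differs from compound 1 by one change: 4-chlorophenyl in place of furan-2-yl on a double-bonded chain carbon bound to a double-bonded chain carbon. Within the data shown here, because no single-place step has been measured, the size and direction of this change in this assay remain open; what is known is that compound 1 sits at a limit, so any real gain could appear only as a number where compound 1 gave none.

Compound 3 is expected to give about 30000 nM in this assay, within an estimated range from 8000 nM to 100000 nM. The step this estimate implies, an at least 1.6-fold lower number from compound 1 to compound 3 (0.22 log units; that floor lies within the scatter), is expected to be small, with a fair chance that a limit is again reported.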

Compound 3, concentration for 50% growth inhibition: 31000 nM
Compound 3: middle estimate off by 1.0-fold (0.01 log units), on the low side; measured number inside the range.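

Swapping furan-2-yl for 4-chlorophenyl on a double-bonded chain carbon bound to a double-bonded chain carbon gives a step in which only one place changes, and it can be read in this assay as an at least 1.6-fold lower number from compound 1 to compound 3 (0.20 log units; that floor lies within the scatter). This step is only a floor, so the real difference may be larger, but it cannot be sized, and compound 1 remains the compound held at a limit rather than a number: the limit of > 50000 nM in this assay, at which 1 of the 3 values shown sits. The new information is that this place can carry a larger aromatic ring with a chlorine on it and still give a measured number, with compound 3 at 31000 nM, though that number still marks a weak inhibitor of growth in absolute terms.

The compounds shown leave open whether any gain belongs to the six-membered ring or to its chlorine, and plain phenyl at this place would separate the two. From the compounds shown here alone, how this assay would respond to a carboxylic acid or an amine on that ring in place of the chlorine is also open, as is whether the same swap would give a similar step on the core of compound 2.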